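The source may hold more compounds than are shown below. What is called first, only, known or untested is meant among the compounds shown, and "the series" means these compounds.

Compounds measured so far in a functional assay on DU-145 cells (Homo sapiens) for inhibition, read by trypan blue exclusion, with a stated time of 96 h; on this read-out higher numbers stand for weaker inhibition of growth and lower numbers for stronger inhibition of growth:

Compound 1, `Cc1ccc(CS(=O)(=O)/C(=C/c2cccc(Cl)c2Cl)C(=O)c2ccc(Cl)cc2)cc1`, gives 1000 nM.
Compound 2, `Cc1ccc(CS(=O)(=O)/C(=C/c2sccc2C)C(=O)c2ccc(Cl)cc2)cc1`, gives 25000 nM.
Compound 3, `Cc1ccc(CS(=O)(=O)/C(=C/c2cc(C)cc(C)c2)C(=O)c2ccc(Cl)cc2)cc1`, gives 10000 nM.

Compound 3 stands second highest of the three numbers. Its nearest neighbour is compound 2: a 2.5-fold lower number from compound 2 to compound 3 (0.40 log units; beyond the scatter). Its furthest is compound 1: a 10-fold higher number from compound 1 to compound 3 (1.00 log units; beyond the scatter). Of the three, compound 1 therefore shows the strongest growth inhibition in this assay, and compound 3 sits well away from it.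

Compound 4, `Cc1ccc(CS(=O)(=O)/C(=C/c2ccc(Cl)cc2)C(=O)c2ccc(Cl)cc2)cc1`, has not yet been measured. It differs from compound 3 in one place only: 4-chlorophenyl in place of 3,5-dimethylphenyl on a double-bonded chain carbon bound to a double-bonded chain carbon

Within the data shown here, no measured step swaps 3,5-dimethylphenyl for 4-chlorophenyl directly. The closest guide is the step from a chlorine-bearing phenyl to the dimethylphenyl, a 10-fold higher number from compound 1 to compound 3 (1.00 log units; beyond the scatter), which went in the direction of weaker growth inhibition when the methyl groups came in and the chlorines left. Compound 4 brings a chlorine-bearing phenyl back, though with a single chlorine in a different place. Among the measured compounds shown here, a step toward a lower number than compound 3 is therefore expected, probably smaller than the one between compound 1 and compound 3 and clearly beyond the scatter. The expected step from compound 3 to compound 4 is a 3.3-fold lower number from compound 3 to compound 4 (0.52 log units; beyond the scatter). Compound 4 is estimated at 3000 nM, with a range from 800 nM to 12000 nM.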

Compound 4, concentration for 50% growth inhibition: 25000 nM
Estimate against measurement, compound 4: 8.3-fold (0.92 log units) below; the measured number lies above the stated range.
By their numbers in this assay, from the lowest: compound 1; then compound 3; then compounds 2 and 4 (each within the scatter of the next).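

A chlorine on this ring does not by itself restore growth inhibition in this assay: the single chlorine of 4-chlorophenyl gives weaker inhibition than the two methyl groups of 3,5-dimethylphenyl (a 2.5-fold higher number from compound 3 to compound 4 (0.40 log units; beyond the scatter)) and much weaker inhibition than 2,3-dichlorophenyl (a 25-fold higher number from compound 1 to compound 4 (1.40 log units; beyond the scatter)). The change from the thiophene ring to 4-chlorophenyl makes no difference that can be read (no change at the digits printed from compound 2 to compound 4 (within the scatter)), so these two different rings cannot be told apart here, and among the four compounds only the 2,3-dichlorophenyl of compound 1 stands clearly apart from the rest. Nothing available here explains why these rings differ in this way.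

Compound 1 and compound 4 differ in both the number of chlorines and where they stand on the ring, so the compounds shown cannot say which of the two matters. From the compounds shown here alone, how a ring carrying an amine or a carboxylic acid would behave on this double-bonded chain carbon also remains open.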